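A few compounds are considered here, and "the series" means these few. Any claim that something is new, unique, unknown or untested is made for them only; others in the source may bear on it.

Compound 1 `O=C1c2ccccc2C(=O)N1C1C=C(C#Cc2ccccn2)CCC1` gives 5.8 nM in an assay for displacement of a labelled ligand from metabotropic glutamate receptor 5 (Rattus norvegicus); a lower number here means a stronger inhibitor, a higher number a weaker inhibitor.
Compound 2 `C(#Cc1ccccn1)C1=CCNCC1` gives 3400 nM in this assay.
Compound 3 `O=S(=O)(Cc1ccccc1)N1CC=C(C#Cc2ccccn2)CC1` gives 389 nM in this assay.

All three share the same pyridylethynyl group on a six-membered ring; they differ in what sits on the ring nitrogen. Compound 3 stands second highest of the three numbers, which means second weakest: compound 2, with a bare ring nitrogen, gives the higher number, and compound 1, with its imide group, gives by far the lowest. Both gaps are beyond the usual scatter.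

Compound 4 `Cc1cccc(S(=O)(=O)N2CC=C(C#Cc3ccccn3)CC2)c1` keeps the sulfonyl group of compound 3 but changes what is attached to it: 3-methylphenyl in place of benzyl on a sulfonyl sulfur. The same atoms are present, joined differently, so the aromatic ring now sits directly on the sulfonyl sulfur.

Going by the values given here, no measured pair shows this exact change, so the expectation rests on compound 3 alone. A modest gain is expected, within the step of a 3.2-fold lower number from compound 3 to compound 4 (0.51 log units; beyond the scatter). Compound 4 is therefore estimated at 120 nM, with a range from 25 nM to 600 nM.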

Compound 4, inhibition constant: 13 nM
Beside the measured number, compound 4's estimate is 9.2-fold (0.97 log units) above it, and the stated range ends above it.
By their numbers in this assay, from the lowest: compound 1; then compound 4; then compound 3; then compound 2.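

On the sulfonyl sulfur, 3-methylphenyl in place of benzyl gives a 30-fold lower number from compound 3 to compound 4 (1.48 log units; beyond the scatter) in this assay. Going by these compounds alone, this is the first change that can be read at a single place, and it shows that activity here depends strongly on how the aromatic group is joined, even though both groups have the same count of heavy atoms and neither has hydrogen-bond donors or acceptors. Nothing measured here accounts for the gain.

Going by these compounds, the step combines two changes, the ring moving directly onto the sulfur and the added methyl group, so their shares remain open. A plain phenyl group on the sulfonyl sulfur would separate them, and a chlorine or methoxy group on that ring would test whether methyl is needed at all.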